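Urea aryl tail on the chlorohydroxyphenyl pyrazole core

The source may report more compounds than this note shows. Statements on the series, on what has been measured and on what is new or still open speak of the compounds shown alone.

Working notes on the series. Compound 1 `O=C(Nc1cccc(-n2cc(-c3ccncc3)c(-c3ccc(Cl)c(O)c3)n2)c1)Nc1cccc(C(F)(F)F)c1` carries a 3-(trifluoromethyl)phenyl urea on the shared core; in a functional assay on SF-295 cells (Homo sapiens) for inhibition, read by sulforhodamine B assay, with a stated time of 48 h (on this read-out higher numbers stand for weaker inhibition and lower numbers for stronger inhibition), compound 1 gives 960 nM. Compound 2 `COc1cc(-c2nn(-c3cccc(NC(=O)Nc4ccc(Cl)c(Cl)c4)c3)cc2-c2ccncc2)ccc1Cl` differs in two places, a methoxy in place of the hydroxy on the core and a 3,4-dichlorophenyl urea in place of the 3-(trifluoromethyl)phenyl urea; in this assay compound 2 gives 690 nM. The two values lie within the usual scatter of each other, so no order between compound 1 and compound 2 can be read from them.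

Compound 3 `O=C(Nc1cccc(-n2cc(-c3ccncc3)c(-c3ccc(Cl)c(O)c3)n2)c1)Nc1ccc(Cl)c(Cl)c1` joins the core of compound 1 to the 3,4-dichlorophenyl urea of compound 2. In this assay, among the compounds with values here, compound 3 gives "not determined" (no result reported), so compound 3 stands without a number and no step between measured compounds that differ in one place can be drawn.

Compound 4 `O=C(Nc1cccc(-n2cc(-c3ccncc3)c(-c3ccc(Cl)c(O)c3)n2)c1)Nc1ccc(Cl)c(C(F)(F)F)c1` has not yet been measured. It differs from compound 3 by trifluoromethyl in place of chloro on an aromatic carbon. Within the data shown here, with no measured step to lean on, the expectation in this assay for compound 4 rests on the values of compound 1 and compound 2 and is a potency near those two, without a step beyond the scatter in either direction. Compound 4 is estimated at 750 nM, within 300 nM to 1900 nM.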

Compound 4, half-maximal inhibitory concentration: 740 nM
Beside the measured number, compound 4's estimate is 1.0-fold (0.01 log units) above it, and the stated range covers the measured number.
By their numbers in this assay, from the lowest: compounds 2, 4 and 1 (each within the scatter of the next).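

In this assay, chloro in place of hydrogen on the aryl tail of the urea gives a 1.3-fold lower number from compound 1 to compound 4 (0.11 log units; within the scatter) and so leaves no readable difference between the 3-(trifluoromethyl)phenyl urea and the 4-chloro-3-(trifluoromethyl)phenyl urea on the shared core. Within the data shown here, this is the first pair that differs in one place, and it shows that this tail position takes an added chloro without a step beyond the scatter, which the two earlier numbers, separated by two changes, could not show. The change from chloro to trifluoromethyl itself cannot be read, since compound 3 has no number to set against compound 4.

Still open, from the compounds shown here alone, is whether any replacement on this aryl tail moves the number beyond the scatter, for example an amine or a carboxylic acid in place of the chloro of compound 4. Also open is what the hydroxy on the core contributes on its own, as no pair shown differs only there.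

No measurement is at hand that bears on the reason for this result.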